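Linker double-bond geometry: from compound 2 to compound 3

The source may hold more compounds than are shown below. What is called first, only, known or untested is meant among the compounds shown, and "the series" means these compounds.

Among the compounds with values here, compound 1 `CCCCC#Cc1cn(C/C=C/CN2C(=O)c3ccccc3C2=O)c(=O)[nH]c1=O` carries the only numerical reading here: in a functional assay on MCF7 cells (Homo sapiens) for antiproliferative activity, read by MTT assay, with a stated time of 3 days (on this read-out lower numbers stand for stronger inhibition and higher numbers for weaker inhibition), compound 1 gives 8800 nM. Compound 2 `CCCCCc1ccc(C#Cc2cn(C/C=C\CN3C(=O)c4ccccc4C3=O)c(=O)[nH]c2=O)cc1` is recorded as a limit of the assay and not a number; in this assay compound 2 gives > 100000 nM, sitting at the limit of > 100000 nM in this assay, at which 1 of the 2 values shown sits. Compound 3 `CCCCCc1ccc(C#Cc2cn(C/C=C/CN3C(=O)c4ccccc4C3=O)c(=O)[nH]c2=O)cc1` is not yet measured. Change from compound 2 to compound 3: the two compounds have the same atoms and bonds and differ only in configuration as drawn: 1 of 1 stereo elements differ; a double bond is drawn Z in compound 2 and E in compound 3. Within the data shown here, no measured pair isolates this change, so no step size is known. In this assay the step is expected to be an at least 3.3-fold lower number from compound 2 to compound 3 (0.52 log units; beyond the scatter), toward stronger inhibition, with a real chance that only a limit is again recorded. Compound 3 is estimated at 30000 nM, within 5000 nM to 100000 nM.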

Compound 3, half-maximal inhibitory concentration: 5600 nM
Compound 3: middle estimate off by 5.4-fold (0.73 log units), on the high side; the measured number falls inside the stated range.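

In this assay the linker double bond alone accounts for an at least 17-fold lower number from compound 2 to compound 3 (1.25 log units; beyond the scatter): the fact that compounds 2 and 3 differ only in the configuration as drawn. Compound 2 is recorded as a limit of the assay, > 100000 nM, so this step has a lower bound only. With the E linker kept, 4-pentylphenyl in place of butyl gives a 1.6-fold lower number from compound 1 to compound 3 (0.20 log units; within the scatter), so these two groups on the triple-bonded carbon are not told apart here.

Going by these compounds, whether the Z-to-E step holds equally with butyl on the triple-bonded carbon stays open. Also open, on these data alone, is how an amine or a carboxylic acid in place of 4-pentylphenyl would read.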